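The source may report more compounds than this note shows. Statements on the series, on what has been measured and on what is new or still open speak of the compounds shown alone.

Measured so far in a functional assay on the whole organism (artery, strain albino) with Rattus norvegicus as the target, with a stated time of 180 min, at a dose of 10 mg/kg by the oral route; on this read-out higher numbers stand for more inhibition at the one dose given (going by the name of the read-out) and lower numbers for less inhibition:
compound 1, `CC1=C(C(=O)Nc2ccc(F)cc2)C(c2ccc([N+](=O)[O-])cc2)N=C(SCc2cccc(Cl)c2)N1`, gives 11.9%
compound 2, `CC1=C(C(=O)Nc2ccc(F)cc2)C(c2ccc([N+](=O)[O-])cc2)N=C(SCc2ccc(Cl)cc2)N1`, gives 23.2%
compound 3, `CC1=C(C(=O)Nc2ccc(Br)cc2)C(c2ccc(Cl)cc2Cl)N=C(SCc2cccc(Cl)c2)N1`, gives 11.9%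

Compound 1 and compound 2 share one core and differ in a single spot: 4-chlorophenyl in place of 3-chlorophenyl on a saturated chain carbon bound to a sulfur. That change made a step of a number 11.3 percentage points higher from compound 1 to compound 2 (beyond the scatter). Compound 3 is built on another core; the difference between the two cores is not broken down here. Compound 4, `CC1=C(C(=O)Nc2ccc(Br)cc2)C(c2ccc(Cl)cc2Cl)N=C(SCc2ccc(Cl)cc2)N1`, has not yet been measured in this assay. Compound 4 stands to compound 3 exactly as compound 2 stands to compound 1, the same change at the same place: 4-chlorophenyl in place of 3-chlorophenyl on a saturated chain carbon bound to a sulfur. Compound 3 sits level with compound 1 at the digits shown. For compound 4 the step expected from this change is a number 11.1 percentage points higher from compound 3 to compound 4 (beyond the scatter), resting on that single earlier step alone. Compound 4 is therefore estimated at 23%, with a likely range from 8% to 38%.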

Compound 4, a percentage reported as inhibition, in the whole organism at one dose (the size of the read-out at that dose, not a potency): 23.2%
The estimate for compound 4 lay 0.2 percentage points below the measured number; the measured number falls inside the stated range.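

In this assay, putting 4-chlorophenyl in place of 3-chlorophenyl gave a number 11.3 percentage points higher from compound 3 to compound 4 (beyond the scatter). Set beside the earlier step, the change carried over from one core to the other with its size intact: the same change on two cores in this assay, a number 11.3 percentage points higher (beyond the scatter) from compound 1 to compound 2 and a number 11.3 percentage points higher (beyond the scatter) from compound 3 to compound 4, 0 percentage points apart, within the scatter of two such steps This shows only that the step held on these two cores at the one dose tested; it does not show that it would hold on a third core, and it does not explain why the change raises the number.

The compounds shown leave open what would happen with an unsubstituted benzyl, a longer chain or an amine at this place. They also leave open whether either core would respond to those groups in the same way.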